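The source may hold more compounds than are shown below. What is called first, only, known or untested is meant among the compounds shown, and "the series" means these compounds.

Measured compounds:
- Compound 1 `Cc1nc2c3ccccc3ccc2c2nc3c(ccc4ccccc43)c(-c3ccccc3S)c12`, 158 ug/mL
- Compound 2 `Cc1ccc(-c2c3ccc4ccccc4c3nc3c2c(C)nc2c4ccccc4ccc32)cc1`, 192 ug/mL
- Compound 3 `Cc1nc2c3ccccc3ccc2c2nc3c(ccc4ccccc43)c(-c3cc([N+](=O)[O-])ccc3N)c12`, 110 ug/mL

In a functional assay, with a stated time of 90 s (on this read-out lower numbers stand for stronger inhibition and higher numbers for weaker inhibition), the number for compound 2 stands at the upper end of the three, but neither step from it is large: a 1.2-fold higher number from compound 1 to compound 2 (0.08 log units; within the scatter) and a 1.7-fold lower number from compound 2 to compound 3 (0.24 log units; within the scatter) both lie within the scatter, as does a 1.4-fold lower number from compound 1 to compound 3 (0.16 log units; within the scatter) between the other two. The three measured compounds therefore look alike on this read-out.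

Compound 4 `Cc1nc2c3ccccc3ccc2c2nc3c(ccc4ccccc43)c(-c3cccc([N+](=O)[O-])c3)c12` has not yet been measured. It differs from compound 2 in one place: 3-nitrophenyl in place of 4-methylphenyl on an aromatic carbon.

The two steps that bear on this change are those leading from and to compound 2. Both were within the scatter, and they involved quite different groups at the same aromatic carbon, including one carrying a nitro group in compound 3. On that basis no step beyond the scatter is expected, and the estimated step is a 1.2-fold lower number from compound 2 to compound 4 (0.08 log units; within the scatter). Compound 4 is expected to give about 160 ug/mL, within a range from 90 ug/mL to 290 ug/mL.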

Compound 4, half-maximal inhibitory concentration: 157 ug/mL
Estimate against measurement, compound 4: 1.0-fold (0.01 log units) above, and the stated range covers the measured number.
By their numbers in this assay, from the lowest: compounds 3, 4, 1 and 2 (each within the scatter of the next).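

In this assay, 3-nitrophenyl on this aromatic carbon, opposite the ring nitrogen, fits the same narrow band as the other substituted phenyl groups: putting it in place of 4-methylphenyl gives a 1.2-fold lower number from compound 2 to compound 4 (0.09 log units; within the scatter), and putting it in place of 2-sulfanylphenyl gives a 1.0-fold lower number from compound 1 to compound 4 (0.00 log units; within the scatter). The new compound also isolates the amino group on the nitro-bearing ring, since hydrogen in place of amino gives a 1.4-fold higher number from compound 3 to compound 4 (0.15 log units; within the scatter), so that group has no effect on this read-out that can be told from the scatter. No measurement shown here explains why these values lie so close together.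

Every compound shown carries a substituted phenyl ring at this carbon. Going by these compounds, it remains open whether a carboxylic acid, a piperidine ring or a longer alkyl chain there would give a step beyond the scatter.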